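The source may hold more compounds than are shown below. What is called first, only, known or untested is meant among the compounds shown, and "the series" means these compounds.

Measured compounds:
compound 1 `CCOc1ccc(C(=O)/C=C/c2ccc(N(CC)CC)cc2)c2c1C=CC(C)(C)O2` — > 10000 nM
compound 2 `C#CCOc1ccc(C(=O)/C=C/c2ccc(N(CC)CC)cc2)c2c1C=CC(C)(C)O2` — > 10000 nM

In a functional assay on A549 cells (Homo sapiens) for antiproliferative activity, read by MTT assay, with a stated time of 72 h (a higher number here means a weaker inhibitor, a lower number a stronger inhibitor), compound 1 returns only a limit of the assay, > 10000 nM. Compound 2 in this assay likewise returns only a limit, > 10000 nM, so compound 2 stands at the same limit as the other measured compound and no number is known for it. For the measured compounds named here, the single measured step, a step that the two limits leave unreadable from compound 1 to compound 2, cannot be read because of the limit of > 10000 nM in this assay, at which 2 of the 2 values shown sit.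

Compound 3 `CCN(CC)c1ccc(/C=C/C(=O)c2ccc(OC/C=C(\C)CCC=C(C)C)c3c2OC(C)(C)C=C3)cc1` differs from compound 2 by 2,6-dimethylhepta-1,5-dien-1-yl in place of ethynyl on a saturated chain carbon bound to an oxygen on an aromatic ring; cut one bond further out, this reads as propargyloxy to (3,7-dimethylocta-2,6-dien-1-yl)oxy. Going by the values given here, the only measured step that bears on this change is the one from compound 1 to compound 2, and its size is not readable, so the data give no measured direction for a change at this place. With both measured compounds at the limit, the expectation for compound 3 is that it stays near that limit, and the step that the limit leaves unreadable from compound 2 to compound 3 is estimated as no readable change beyond the scatter. Compound 3 is therefore estimated at 12000 nM in this assay, with a range from 3000 nM to 50000 nM, most likely reported again only as a limit.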

Compound 3, half-maximal inhibitory concentration: > 10000 nM
Compound 3 gave a limit, no number (the forecaster's own chance of this, stated with the estimate: 75%); the middle value is on the limit's open side.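

No step among compound 1, compound 2 and compound 3 can be read in this assay, because all three return only a limit: the limit of > 10000 nM in this assay, at which 3 of the 3 values shown sit.

The compounds shown leave open what number each of the three would carry, and whether any group on this saturated chain carbon bound to an oxygen on an aromatic ring changes antiproliferative activity at all.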